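Two Chlorines in Place of One Fluorine on the Same Ring

This account rests on a few compounds, and the source may have more. Where it says the series, first, only, none or still open, it means among the compounds named here.

Compound 1 `Fc1ccc(C2=NN(C(=S)Nc3ccccc3)C(c3ccc4c(c3)OCCO4)C2)cc1` was tested in a functional assay on WM 266-4 cells (Homo sapiens) for antiproliferative activity, read by MTT assay, with a stated time of 48 h (a lower number here means a stronger inhibitor of growth, a higher number a weaker inhibitor of growth), where compound 1 gives 22500 nM. Of the two values available, this is the highest, so compound 1 is the weaker of the two growth inhibitors. Among the measured compounds shown here, its only measured neighbour is compound 2 `Cc1ccc(C2=NN(C(=S)Nc3ccccc3)C(c3ccc4c(c3)OCCO4)C2)cc1`, which in this assay gives 10300 nM; the single difference between the two is a 2.2-fold lower number from compound 1 to compound 2 (0.34 log units; beyond the scatter).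

Compound 3 `S=C(Nc1ccccc1)N1N=C(c2ccc(Cl)c(Cl)c2)CC1c1ccc2c(c1)OCCO2` has not yet been measured. It differs from compound 1 in one place: 3,4-dichlorophenyl in place of 4-fluorophenyl on a carbon with a double bond to nitrogen. For the measured compounds named here, the one measured step that bears on this change is the exchange on the same aromatic ring, a 2.2-fold lower number from compound 1 to compound 2 (0.34 log units; beyond the scatter), which shows that altering the substituent on that ring moved the number modestly toward stronger inhibition. The change to compound 3 also removes the 4-fluorophenyl, so a modest step in the same direction as a 2.2-fold lower number from compound 1 to compound 2 (0.34 log units; beyond the scatter) is expected, though with wide uncertainty, as no dichlorophenyl has yet been measured. Compound 3 is therefore estimated to give 12000 nM in this assay, within 4000 nM to 36000 nM, which is expected to mean a 1.9-fold lower number from compound 1 to compound 3 (0.27 log units; within the scatter).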

Compound 3, concentration for 50% growth inhibition: 58700 nM
Compound 3: the middle estimate sits 4.9-fold (0.69 log units) below what was measured, and the stated range ends below it.
By their numbers in this assay, from the lowest: compound 2; then compound 1; then compound 3.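

In this assay, the exchange of 4-fluorophenyl for 3,4-dichlorophenyl moves the number the opposite way from the earlier exchange on this ring (a 2.6-fold higher number from compound 1 to compound 3 (0.42 log units; beyond the scatter)), and the gap to the 4-methylphenyl compound is wider still (a 5.7-fold higher number from compound 2 to compound 3 (0.76 log units; beyond the scatter)). The earlier pair could suggest that moving away from 4-fluorophenyl strengthens growth inhibition, but these three compounds show that the number at this position, on a carbon with a double bond to nitrogen, can move in either direction depending on the group that enters. Compound 3 is the weakest growth inhibitor of the three, since both of its steps lie beyond the scatter, but nothing available explains this order.

The change to compound 3 replaces one fluorine with two chlorines, so these results cannot show whether one chlorine or the pair accounts for the higher number, and a 4-chlorophenyl group would help separate the two. From the compounds shown here alone, it also remains open how this position would respond to a ring carrying an amine or a carboxylic acid, or to a longer chain such as 4-butylphenyl.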